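From methoxy to hydroxy in compound 3

This account rests on a few compounds, and the source may have more. Where it says the series, first, only, none or still open, it means among the compounds named here.

In a functional assay on HT-1080 cells (Homo sapiens) for cytotoxicity, read by MTT assay, with a stated time of 72 h (on this read-out lower numbers stand for stronger inhibition and higher numbers for weaker inhibition), compound 2 (`COc1cccc(/C=C2\CCC/C(=C\c3cccc(OC)c3OC)C2=O)c1`) gives 9900 nM and lies within the scatter of compound 1 (`COc1cccc(/C=C2\CCC/C(=C\c3cccc(Cl)c3)C2=O)c1OC`) at 10300 nM with neither set apart. Compound 3 (`COc1cccc(/C=C2\CCC/C(=C\c3cccc(O)c3)C2=O)c1OC`) differs from compound 2 by hydrogen in place of methyl on an oxygen on an aromatic ring, 3-methoxyphenyl to 3-hydroxyphenyl (hydrogen in place of methyl on an oxygen on an aromatic ring). Within the data shown here, the one measured step (a 1.0-fold lower number from compound 1 to compound 2 (0.02 log units; within the scatter)) stayed within the scatter, but it involved no hydroxy group, so it offers only weak guidance. In this assay the expected step (a 1.2-fold lower number from compound 2 to compound 3 (0.09 log units; within the scatter)) is small, leaning toward a lower number without leaving the scatter. Compound 3 is estimated at 8000 nM with an expected range from 3000 nM to 20000 nM in this measurement.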

Compound 3, half-maximal inhibitory concentration: 8500 nM
Compound 3: the middle estimate sits 1.1-fold (0.03 log units) below what was measured; the measured number falls inside the stated range.
By their numbers in this assay, from the lowest: compounds 3, 2 and 1 (each within the scatter of the next).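

In this assay the step of a 1.2-fold lower number from compound 2 to compound 3 (0.07 log units; within the scatter) shows that this oxygen on an aromatic ring can carry hydrogen in place of methyl without leaving the scatter, which the earlier pair, lacking a hydroxy group, could not show. The step of a 1.2-fold lower number from compound 1 to compound 3 (0.08 log units; within the scatter) reads the same way, so chloro, methoxy and hydroxy are not told apart here. Nothing available explains this flat result. Going by these compounds, whether an amine or a carboxylic acid in this place would also leave the number within the scatter remains open.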